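The source may hold more compounds than are shown below. What is called first, only, known or untested is meant among the compounds shown, and "the series" means these compounds.

Measured in a functional assay on MDA-MB-231 cells (Homo sapiens) for inhibition, read by MTT assay, with a stated time of 48 h; on this read-out lower numbers stand for stronger inhibition of growth and higher numbers for weaker inhibition of growth:
- Compound 1 `Oc1ccc(NC(=S)Nc2ccc3ncnc(Nc4cccc(Br)c4)c3c2)cc1`: 17300 nM.
- Compound 2 `NS(=O)(=O)c1ccc(NC(=S)Nc2ccc3ncnc(Nc4cccc(Br)c4)c3c2)cc1`: > 30000 nM, a limit.
- Compound 3 `CNC(=S)Nc1ccc2ncnc(Nc3cccc(Br)c3)c2c1`: > 30000 nM, a limit.

Compound 3 has no exact number in this assay, only the limit > 30000 nM. Overall, the data show (the limit of > 30000 nM in this assay, at which 2 of the 3 values shown sit).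

Compound 4 `S=C(NCc1ccc(Cl)cc1)Nc1ccc2ncnc(Nc3cccc(Br)c3)c2c1` differs from it by 4-chlorophenyl in place of hydrogen on a saturated chain carbon bound to an amide-type nitrogen. In other words, methyl becomes 4-chlorobenzyl.

The closest measured change is an at least 1.7-fold higher number from compound 1 to compound 3 (0.23 log units; that floor lies within the scatter), where methyl replaces 4-hydroxyphenyl. Read in reverse, it gives a weak hint that a larger aromatic group could lower the number. Within the data shown here, compound 1 is the only compound with an exact number, 17300 nM.

Compound 2 goes against that hint, with its limit of > 30000 nM. The related at least 1.7-fold higher number from compound 1 to compound 2 (0.23 log units; that floor lies within the scatter) shows how much the ring's substituent may matter, and a step that the two limits leave unreadable from compound 2 to compound 3 adds nothing readable.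

A modest move towards lower numbers is therefore expected, and another limit remains possible. For compound 4, the estimated value is 15000 nM, with an expected range from 6000 nM to 30000 nM. This expectation amounts to an at least 2.0-fold lower number from compound 3 to compound 4 (0.30 log units; that floor lies within the scatter).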

Compound 4, concentration for 50% growth inhibition: 23000 nM
Compound 4: the middle estimate sits 1.5-fold (0.19 log units) below what was measured; measured number inside the range.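

In this assay compound 4 gives an exact number where compound 3, with its methyl, gave only a limit, so a 4-chlorobenzyl group on this amide-type nitrogen brings the compound into the measurable range. Two steps lead to it, an at least 1.3-fold lower number from compound 3 to compound 4 (0.11 log units; that floor lies within the scatter) and an at least 1.3-fold lower number from compound 2 to compound 4 (0.11 log units; that floor lies within the scatter), and both are only floors, because the starting compounds carry limits rather than numbers: the limit of > 30000 nM in this assay, at which 2 of the 4 values shown sit. The third step, a 1.3-fold higher number from compound 1 to compound 4 (0.12 log units; within the scatter), means that 4-chlorobenzyl and 4-hydroxyphenyl cannot be told apart here, so a ring on this nitrogen does not need to be a directly attached phenyl to give a number.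

Going by these compounds, it remains open what a plain benzyl group, a 2-phenylethyl group or a benzyl group carrying an amine in place of the chlorine would give. On these data alone, the chlorine's own share in the result for compound 4 also stays unknown.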